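A few compounds are considered here, and "the series" means these few. Any claim that something is new, unique, unknown or untested is made for them only; others in the source may bear on it.

Of the compounds shown here, three of a shared core have been measured in a functional assay on SK-N-SH cells (Homo sapiens) for inhibition, read by MTT assay; on this read-out higher numbers stand for weaker inhibition and lower numbers for stronger inhibition. Compound 1 `CCCCCCCCn1cc(/C=C/C(=O)c2ccc(NC(=O)CN3CCN(C(=O)OC(C)(C)C)CC3)cc2)nn1` gives 38000 nM, compound 2 `CC(C)(C)OC(=O)N1CCN(CC(=O)Nc2ccc(C(=O)/C=C/c3cn(Cc4ccc(Br)cc4)nn3)cc2)CC1` gives 25800 nM, and compound 3 `CCCCCCCCCCn1cc(/C=C/C(=O)c2ccc(NC(=O)CN3CCN(C(=O)OC(C)(C)C)CC3)cc2)nn1` gives 77800 nM. Compound 3 therefore stands at the highest number of the three: the step of a 2.0-fold higher number from compound 1 to compound 3 (0.31 log units; beyond the scatter) is modest but beyond the scatter, as is a 3.0-fold higher number from compound 2 to compound 3 (0.48 log units; beyond the scatter), while a 1.5-fold lower number from compound 1 to compound 2 (0.17 log units; within the scatter) stays within the scatter. All three of these steps concern the group on the saturated chain carbon bound to the aromatic nitrogen at one end of the core.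

Compound 4 `CCCCCCCCCCn1cc(/C=C/C(=O)c2ccc(NC(=O)CN3CCN(c4ccccc4OC)CC3)cc2)nn1` alters the other end of the core instead: 2-methoxyphenyl in place of tert-butoxycarbonyl on an amine nitrogen in a ring. Within the data shown here, none of the measured steps touches this amine nitrogen, so no step bears directly on the change; the measured series offers no precedent for swapping a tert-butoxycarbonyl for an aryl group at that position. With nothing to support a move in either direction, the expected step of a 1.3-fold lower number from compound 3 to compound 4 (0.11 log units; within the scatter) from compound 3 is one that need not exceed the scatter, but the range around it must be wide. Compound 4 is estimated at 60000 nM in this assay, expected to fall between 15000 nM and 240000 nM.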

Compound 4, half-maximal inhibitory concentration: 87600 nM
The estimate for compound 4 lay 1.5-fold (0.16 log units) below the measured number; the range from low to high includes it.
By their numbers in this assay, from the lowest: compounds 2 and 1 (each within the scatter of the next); then compounds 3 and 4 (each within the scatter of the next).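

In this assay, among these compounds, the first change at the amine nitrogen in the ring, 2-methoxyphenyl in place of tert-butoxycarbonyl, gives a 1.1-fold higher number from compound 3 to compound 4 (0.05 log units; within the scatter) and so leaves the two compounds within the scatter of each other. The exchange is a large one by what can be counted: a group with no ring, a double bond outside aromatic rings and two hydrogen-bond acceptors leaves, and a group with a six-membered aromatic ring of carbon only and one hydrogen-bond acceptor enters, yet this single pair shows no step beyond the scatter at this position. Nothing measured here accounts for how closely the two numbers agree.

The compounds shown leave open whether a plain hydrogen, an acetyl group or an unsubstituted phenyl on this amine nitrogen would also stay within the scatter of compound 3. They also leave open whether 2-methoxyphenyl would give a similarly small step when paired with the other end of compound 2, which stands at 25800 nM in this assay and carries the 4-bromophenyl group.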